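Aryl variation on the oxadiazole-linked trifluoromethyl ketone series

The source may hold more compounds than are shown below. What is called first, only, known or untested is meant among the compounds shown, and "the series" means these compounds.

Measured so far:
compound 1 `Cc1ccc(-c2noc(-c3ccc(C(=O)C(F)(F)F)s3)n2)cc1` — 110 nM
compound 2 `O=C(c1ccc(-c2nc(-c3cccc(C(F)(F)F)c3)no2)s1)C(F)(F)F` — 320 nM
compound 3 `O=C(c1ccc(-c2nc(-c3ccc(C(F)(F)F)cc3)no2)s1)C(F)(F)F` — 200 nM

In an assay for inhibition of histone deacetylase 4 (Homo sapiens) (a higher number here means a weaker inhibitor, a lower number a stronger inhibitor), compound 1 gives 110 nM, the lowest of the three numbers. Its nearest neighbour is compound 3, which gives 200 nM; the step of a 1.8-fold higher number from compound 1 to compound 3 (0.26 log units; within the scatter) stays within the scatter, so the two cannot be ordered. Compound 2, which also carries a trifluoromethyl on its phenyl, gives 320 nM, a gap from compound 1 that lies beyond the scatter.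

Compound 4 `O=C(c1ccc(-c2nc(-c3ccc(Cl)cc3Cl)no2)s1)C(F)(F)F` is not yet measured. Relative to compound 1 the change is 2,4-dichlorophenyl in place of 4-methylphenyl on an aromatic carbon.

Among the measured compounds shown here, only the step of a 1.8-fold higher number from compound 1 to compound 3 (0.26 log units; within the scatter) bears directly on a swap of the substituent on this phenyl, and it was within the scatter; the difference between compound 1 and compound 2 shows that aryl changes can move the number beyond the scatter, but no measured step covers a chlorine or a second substituent on this ring. The expectation is therefore a modest rise or no change beyond the scatter.

Compound 4 is estimated at 200 nM, with a range from 70 nM to 600 nM; the expected step is a 1.8-fold higher number from compound 1 to compound 4 (0.26 log units; within the scatter).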

Compound 4, half-maximal inhibitory concentration: 240 nM
Estimate against measurement, compound 4: 1.2-fold (0.08 log units) below; the range from low to high includes it.
By their numbers in this assay, from the lowest: compounds 1, 3, 4 and 2 (each within the scatter of the next, the first and the last beyond it).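

In this assay, 2,4-dichlorophenyl in place of 4-methylphenyl gives a 2.2-fold higher number from compound 1 to compound 4 (0.34 log units; beyond the scatter), which shows that a ring with two chlorines on this aromatic carbon keeps a measurable inhibitory value but moves modestly away from compound 1. The replacement with trifluoromethyl gave a 1.8-fold higher number from compound 1 to compound 3 (0.26 log units; within the scatter), so at this position a change of phenyl substituents can either stay within the scatter or leave it, and compound 4 falls with compound 2 among the compounds set beyond the scatter of compound 1. Nothing shown offers an explanation for this step, and the data give no measured property of either group that could be tied to it.

The two chlorines enter together, so the compounds shown leave open how much of the step belongs to either chlorine, and a phenyl carrying a single chlorine would separate the two. Also open is how this position responds to groups of another kind, such as an amine or a carboxylic acid on the phenyl, since every substituent shown here is a methyl, a trifluoromethyl or a chlorine.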